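From compound 1 to a dichlorothiophene analogue

This account rests on a few compounds, and the source may have more. Where it says the series, first, only, none or still open, it means among the compounds named here.

Among the measured compounds shown here, in a functional assay on HUVEC cells (Homo sapiens), read by BrdU incorporation, with a stated time of 72 h (on this read-out lower numbers stand for stronger inhibition and higher numbers for weaker inhibition), compound 1 (`Cc1ccc2nc(Cl)c(/C=C/C(=O)c3ccc(Cl)s3)cc2c1`) gives 59.4 nM and so holds the lowest of the three numbers measured so far. Compound 3 (`Cc1ccc2cc(/C=C/C(=O)c3ccc(I)s3)c(Cl)nc2c1`) gives 135 nM and compound 2 (`Cc1cccc2cc(/C=C/C(=O)c3ccc(I)s3)c(Cl)nc12`) gives 284 nM on the same read-out, and both gaps to compound 1 lie beyond the usual scatter of repeated measurements.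

The next molecule, compound 4 (`Cc1ccc2nc(Cl)c(/C=C/C(=O)c3cc(Cl)sc3Cl)cc2c1`), keeps the core of compound 1 and changes one group on a carbonyl carbon: 2,5-dichlorothiophen-3-yl stands in place of 5-chlorothiophen-2-yl (2,5-dichlorothiophen-3-yl in place of 5-chlorothiophen-2-yl on a carbonyl carbon). For the measured compounds named here, no measured pair isolates a swap of this kind, so the data give no direct guide to its effect. Three compounds offer only a rough hint. Going by the values given here, compound 1 at 59.4 nM sits at the low end of the numbers so far, so a new group seems more likely to raise the number than to lower it. A moderate step toward weaker inhibition is therefore expected in this assay, estimated as a 2.2-fold higher number from compound 1 to compound 4 (0.34 log units; beyond the scatter) on this thin evidence. For compound 4 the estimated half-maximal inhibitory concentration is 130 nM and the expected range runs from 45 nM up to 400 nM at the weak end.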

Compound 4, half-maximal inhibitory concentration: 26.2 nM
Compound 4: middle estimate off by 5.0-fold (0.70 log units), on the high side, and the stated range ends above it.
By their numbers in this assay, from the lowest: compound 4; then compound 1; then compound 3; then compound 2.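

Replacing 5-chlorothiophen-2-yl with 2,5-dichlorothiophen-3-yl on the carbonyl carbon gives a 2.3-fold lower number from compound 1 to compound 4 (0.36 log units; beyond the scatter) in this assay, and this is the first step among these compounds that follows a change in one place only. It shows that this position accepts a different thiophene group and that the change can lower the number rather than raise it, with the entering group carrying two chlorine atoms where the leaving group carries one and joining the carbonyl carbon through a different ring carbon, as the two names show. Nothing available here accounts for the lower number, so the result remains an observation without an explanation.

Among the compounds shown here, the single step cannot separate the effect of the extra chlorine from that of the changed ring attachment, so it remains open which of the two matters, or whether both do. As far as these compounds go, it is also open how this position would respond if a methyl group, a nitrile or an amine took the place of a chlorine on the thiophene ring.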